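The source may hold more compounds than are shown below. What is called first, only, known or untested is meant among the compounds shown, and "the series" means these compounds.

Working notes on the series. Compound 1 `FC1(F)CCC(CN(C[C@H]2Cc3c(cccc3N3CCNCC3)CN2)[C@H]2CCCc3cccnc32)CC1` stands at the higher end of the two numbers in hand: in a functional assay on CCRF-CEM cells for antagonist activity at C-X-C chemokine receptor type 4 (Homo sapiens), read by calcium flux, with stated times of 25 min and 90 s (a higher number here means a weaker inhibitor, a lower number a stronger inhibitor), compound 1 gives 498 nM. Compound 2 `CN(C[C@H]1Cc2c(cccc2N2C[C@@H]3C[C@H]2CN3)CN1)[C@H]1CCCc2cccnc21` differs from compound 1 at several places, not just one. In this assay compound 2 gives 146 nM. Compound 3 `c1cnc2c(c1)CCC[C@@H]2N(CC1CCCCC1)C[C@H]1Cc2c(cccc2N2CCNCC2)CN1` differs from compound 1 by cyclohexyl in place of 4,4-difluorocyclohexyl on a saturated chain carbon bound to an amine nitrogen. Among the measured compounds shown here, no measured pair shows this change, and the step from the difluoro to the plain ring is expected to stay within the scatter, with a 1.2-fold higher number from compound 1 to compound 3 (0.08 log units; within the scatter) as the estimated step. Compound 3 is therefore expected to give about 600 nM in this assay, between 250 nM and 1500 nM.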

Compound 3, half-maximal inhibitory concentration: 715 nM
Compound 3: the middle estimate sits 1.2-fold (0.08 log units) below what was measured; the range from low to high includes it.
By their numbers in this assay, from the lowest: compound 2; then compounds 1 and 3 (each within the scatter of the next).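

In this assay, among the compounds shown here, the first single-place comparison gives a 1.4-fold higher number from compound 1 to compound 3 (0.16 log units; within the scatter), so cyclohexyl and 4,4-difluorocyclohexyl on a saturated chain carbon bound to an amine nitrogen cannot be told apart. At this position, the two fluorine atoms therefore make no difference beyond the scatter. No available evidence bears on the reason for this result. As far as these compounds go, whether an amine or a carboxylic acid on the cyclohexyl ring, or a longer chain in its place, would also leave the number within the scatter remains open. The value of compound 2 cannot be assigned to any single place, since it differs from compound 1 at several.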